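The source may report more compounds than this note shows. Statements on the series, on what has been measured and on what is new or still open speak of the compounds shown alone.

Among the compounds with values here, in a functional assay on HCC827 cells (Homo sapiens) for antiproliferative activity, read by MTT assay, with a stated time of 72 h (on this read-out lower numbers stand for stronger inhibition and higher numbers for weaker inhibition), compound 2 `CN1CCN(c2ccc(Nc3ncc4nc(Sc5ccccc5)n(C5CCCC5)c4n3)cc2)CC1` gives 51.2 nM and so holds the lower of the two numbers so far, clearly under compound 1 `CN1CCN(c2ccc(Nc3ncc4nc([S+]([O-])c5ccccc5)n([C@H]5CC[C@H](O)CC5)c4n3)cc2)CC1` with its 268 nM on the same read-out. Compound 3 `CN1CCN(c2ccc(Nc3ncc4nc(Sc5ccccc5)n([C@H]5CC[C@H](O)CC5)c4n3)cc2)CC1` keeps the shared core and the phenylsulfanyl group of compound 2 but has 4-hydroxycyclohexyl in place of cyclopentyl on an aromatic nitrogen. Compound 1 also carries 4-hydroxycyclohexyl, but it differs from compound 2 elsewhere too, so those two values do not isolate this change. The expected change is small, with a 1.3-fold lower number from compound 2 to compound 3 (0.11 log units; within the scatter) as the estimate, toward a slightly lower number but within the usual scatter. Compound 3 is therefore expected at 40 nM with an estimated range from 10 nM to 150 nM as the likely span.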

Compound 3, half-maximal inhibitory concentration: 42.6 nM
Compound 3: the middle estimate sits 1.1-fold (0.03 log units) below what was measured; low and high end bracket the measured number.
By their numbers in this assay, from the lowest: compounds 3 and 2 (each within the scatter of the next); then compound 1.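

In this assay, the step with 4-hydroxycyclohexyl in place of cyclopentyl on the aromatic nitrogen is a 1.2-fold lower number from compound 2 to compound 3 (0.08 log units; within the scatter) and so shows that this position takes the six-membered ring and its hydroxyl with no change beyond the scatter. With 4-hydroxycyclohexyl present in both compounds, phenylsulfanyl in place of the group with an extra oxygen on sulfur gives a 6.3-fold lower number from compound 1 to compound 3 (0.80 log units; beyond the scatter) and so accounts for a change beyond the scatter. No measurement available here explains either step.

Going by these compounds, whether 4-aminocyclohexyl or an open chain such as isopropyl would fare alike on this nitrogen stays open. The compounds shown also do not separate the effect of the hydroxyl from that of the larger ring.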